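The compounds below may be only part of what the source reports. "The series", "measured", "known", "first", "only" and "open" are said of these compounds alone.

Compound 1 `N#CC1=C(N)Oc2c(c3nc4ccccc4nc3c3ccccc23)C12C(=O)N(Cc1cnnn1-c1ccccc1Br)c1ccccc12` gives > 50000 nM in a functional assay on HCT-116 cells (Homo sapiens) for antiproliferative activity, read by MTT assay, with a stated time of 48 h; on this read-out lower numbers stand for stronger inhibition and higher numbers for weaker inhibition.
Compound 2 `COc1ccccc1-n1nncc1CN1C(=O)C2(C(C#N)=C(N)Oc3c(N)cc4nc5ccccc5nc4c32)c2ccccc21` gives > 50000 nM in this assay.

Both of these values are limits of this assay and not numbers. Compound 2 therefore stands at the limit of this assay, the same place where the limit of > 50000 nM in this assay, at which 2 of the 2 values shown sit, puts every value shown here, so nothing separates it from compound 1 on these numbers. Compound 3 `N#CC1=C(N)Oc2c(N)cc3nc4ccccc4nc3c2C12C(=O)N(Cc1cnnn1-c1cc(Cl)ccc1Cl)c1ccccc12` differs from compound 2 in one place: 2,5-dichlorophenyl in place of 2-methoxyphenyl on an aromatic nitrogen.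

Within the data shown here, no measured step between two compounds is available, and both values shown are limits. On that basis the step from compound 2 to compound 3 is expected to be a step that the limit leaves unreadable from compound 2 to compound 3, that is, none beyond the scatter of this assay. Compound 3 is accordingly expected to give 80000 nM in this assay, within a range from 20000 nM to 300000 nM, and most probably to be reported once more only as a limit.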

Compound 3, half-maximal inhibitory concentration: > 50000 nM
Compound 3 ended at the assay's limit; the forecaster's own chance of this, stated with the estimate: 85%; the middle value is on the limit's open side.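

In this assay compound 3 gives > 50000 nM, a limit and not a number. No step can be read between compound 2 and compound 3, and all compounds shown sit at one place: the limit of > 50000 nM in this assay, at which 3 of the 3 values shown sit.

The compounds shown leave open whether any of them differs from another in this assay, and which change would give a value that is a number.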